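A few compounds are considered here, and "the series" means these few. Any claim that something is new, unique, unknown or untested is made for them only; others in the source may bear on it.

Two compounds of the series have been run in an ADME assay on the whole organism (Mus musculus, strain ICR) for pharmacokinetics, read by HPLC, at a dose of 25 mg/kg by the oral route; a lower number here means less compound in the circulation, a higher number more compound in the circulation at the dose given. Compound 1 `CCc1nc2ccc(Cl)cn2c1C(=O)NCc1ccc(N2CCN(CC3CCCCC3)CC2)cc1` gives 53800 ng.h/mL there; compound 2 `CCc1nc2ccc(Cl)cn2c1C(=O)NCc1ccc(N2CC3CN(CC4CCCCC4)CC3C2)cc1` gives 9050 ng.h/mL, the lower of the two numbers, and its gap to compound 1 lies beyond the usual scatter. Compound 3 `CCc1nc2ccc(Cl)cn2c1C(=O)NCc1ccc(N2CC3CN(Cc4ccc(OC(F)(F)F)cc4)CC3C2)cc1` differs from compound 2 in one place: 4-(trifluoromethoxy)phenyl in place of cyclohexyl on a saturated chain carbon bound to an amine nitrogen in a ring. Going by the values given here, no measured pair carries this change, so its effect is open. The expected step of a 1.3-fold lower number from compound 2 to compound 3 (0.11 log units; within the scatter) in this assay is judged small, with no direction that should clear the scatter. Compound 3 is accordingly estimated at 7000 ng.h/mL, within a range from 2000 ng.h/mL to 25000 ng.h/mL.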

Compound 3, area under the concentration-time curve in the Mus musculus assay: 19800 ng.h/mL
Beside the measured number, compound 3's estimate is 2.8-fold (0.45 log units) below it; the range from low to high includes it.
By their numbers in the Mus musculus assay, from the lowest: compound 2; then compound 3; then compound 1.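

In the Mus musculus assay the position on a saturated chain carbon bound to an amine nitrogen in a ring now has a measured step: 4-(trifluoromethoxy)phenyl in place of cyclohexyl gives a 2.2-fold higher number from compound 2 to compound 3 (0.34 log units; beyond the scatter), so an aromatic ring is accepted there without loss of exposure. In a physicochemical assay for solubility, read by HPLC, with a stated time of 12 h, at pH 2 (a higher number here means a more soluble compound, a lower number a less soluble compound), compound 2 gives 628 ug/mL and compound 3 gives 1130 ug/mL, a pair within the usual scatter. Nothing available explains the exposure step.

Open, as far as these compounds go, is whether a plain phenyl or a carboxylic acid at this place would give a similar number. Also open, from the compounds shown here alone, is whether the same change would carry over to the core of compound 1.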